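This account rests on a few compounds, and the source may have more. Where it says the series, first, only, none or still open, it means among the compounds named here.

Of the compounds shown here, two of a shared core have been measured in a functional assay on Jurkat cells for inhibition of nuclear factor NF-kappa-B complex (Homo sapiens); on this read-out lower numbers stand for stronger inhibition and higher numbers for weaker inhibition. Compound 1 `CCOC(=O)c1cnc(C(F)(F)F)nc1NN1C(=O)C=C(C)C1=O` gives 1000 nM in this assay, and compound 2 `CCOC(=O)c1cnc(-c2ccccc2)nc1NN1C(=O)C=C(C)C1=O` gives 100 nM. Within the data shown here, compound 1 thus stands highest of the two, meaning the weaker inhibitor of the pair: the single change of phenyl in place of trifluoromethyl on an aromatic carbon brought a 10-fold lower number from compound 1 to compound 2 (1.00 log units; beyond the scatter), a change well beyond the scatter.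

Compound 3 `CCOC(=O)c1cnc(-c2cccs2)nc1NN1C(=O)C=C(C)C1=O` is not yet measured. It differs from compound 1 in one place: thiophen-2-yl in place of trifluoromethyl on an aromatic carbon. Among the measured compounds shown here, only the step from compound 1 to compound 2 bears on this change, since there a flat aromatic ring likewise replaced trifluoromethyl at the same aromatic carbon, and it brought a 10-fold lower number from compound 1 to compound 2 (1.00 log units; beyond the scatter). A five-membered aromatic ring entering in place of the same group is therefore expected to move the number in the same direction and by a similar amount, although no second ring of this kind has been measured, so the size is uncertain. Compound 3 is expected to give about 150 nM in this assay, within a range of 50 nM to 500 nM, which would be a 6.7-fold lower number from compound 1 to compound 3 (0.82 log units; beyond the scatter).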

Compound 3, half-maximal inhibitory concentration: 20 nM
Compound 3: middle estimate off by 7.5-fold (0.88 log units), on the high side; the measured number lies below the stated range.
By their numbers in this assay, from the lowest: compound 3; then compound 2; then compound 1.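

At the aromatic carbon between two ring nitrogen atoms, replacing trifluoromethyl with thiophen-2-yl gives a 50-fold lower number from compound 1 to compound 3 (1.70 log units; beyond the scatter) in this assay and is the largest step among these compounds, so this position can tolerate far more change in the number than the first pair revealed. The identity of the incoming ring also matters, not just the presence of an aromatic ring in place of trifluoromethyl: swapping phenyl for thiophen-2-yl gives a 5.0-fold lower number from compound 2 to compound 3 (0.70 log units; beyond the scatter) and this step is itself beyond the usual scatter. The data offer no measured property that accounts for the advantage of the five-membered, sulfur-containing ring over phenyl.

Going by these compounds, it remains open whether the low number belongs to thiophen-2-yl specifically or extends to other aromatic rings at this position, such as a furan or a pyridine, and whether a substituent on the thiophene ring, for example a chlorine atom or a methyl group, would lower or raise it further. On these data alone, it is equally open whether a non-aromatic group here, such as a morpholine or a simple amine, would hold the number down, or how thiophen-2-yl would fare with a carboxylic acid in place of the ethoxycarbonyl group.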